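The source may report more compounds than this note shows. Statements on the series, on what has been measured and on what is new or still open speak of the compounds shown alone.

Compound 3 `CCOC(=O)c1sc(-c2ccncc2)nc1N1CCC(NCc2ccc(C(F)(F)F)cc2)CC1` is one of three close relatives tested so far. In an ADME assay on RAW264.7 cells (Mus musculus) for cytotoxicity, read by MTT assay, with a stated time of 72 h, tested at 50 uM (on this read-out higher numbers stand for more inhibition at the one concentration tested (going by the name of the read-out) and lower numbers for less inhibition), compound 3 gives 18.1%, the second highest of the three numbers: compound 2 `CCOC(=O)c1sc(-c2ccncc2)nc1N1CCC(NCc2ccc(F)cc2)CC1` gives 17.5%, within the usual scatter of compound 3, while compound 1 `CCOC(=O)c1sc(-c2ccccn2)nc1N1CCC(NCc2ccc(Cl)c(Cl)c2)CC1` gives 30.1%, beyond it. Compound 4 `CCOC(=O)c1sc(-c2ccncc2)nc1N1CCC(NCc2ccc(Cl)c(Cl)c2)CC1` differs from compound 3 in one place: 3,4-dichlorophenyl in place of 4-(trifluoromethyl)phenyl on a saturated chain carbon bound to an amine nitrogen. Within the data shown here, the only measured step at this position, a number 0.6 percentage points higher from compound 2 to compound 3 (within the scatter), lies within the scatter. Compound 1 carries the same 3,4-dichlorobenzyl group but differs from compound 4 elsewhere as well, so no step can be read from it. Compound 4 is therefore expected to give about 24%, between 12% and 36%, an expected step of a number 5.9 percentage points higher from compound 3 to compound 4 (within the scatter).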

Compound 4, a percentage reported as inhibition, at one concentration (the size of the read-out at that concentration, not a potency): 32.2%
Compound 4: the middle estimate sits 8.2 percentage points below what was measured; the range from low to high includes it.
By their numbers in this assay, from the lowest: compounds 2 and 3 (each within the scatter of the next); then compounds 1 and 4 (each within the scatter of the next).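

In this assay this position responds to the group it carries: 3,4-dichlorophenyl in place of 4-(trifluoromethyl)phenyl gives a number 14.1 percentage points higher from compound 3 to compound 4 (beyond the scatter) and in place of 4-fluorophenyl gives a number 14.7 percentage points higher from compound 2 to compound 4 (beyond the scatter) while the earlier step of a number 0.6 percentage points higher from compound 2 to compound 3 (within the scatter) showed no such change. With the 3,4-dichlorobenzyl group held fixed, pyridin-4-yl in place of pyridin-2-yl gives a number 2.1 percentage points higher from compound 1 to compound 4 (within the scatter) so this swap shows no clear change. Nothing measured here explains the rise at the benzyl position. Still open, from the compounds shown here alone, is whether a 4-chlorophenyl group would match 3,4-dichlorophenyl, and how a 4-methoxyphenyl group or a carboxylic acid on this ring would read.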